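The source may hold more compounds than are shown below. What is called first, only, known or untested is meant among the compounds shown, and "the series" means these compounds.

Within the data shown here, in a functional assay on OE19 cells (Homo sapiens) for antiproliferative activity, with a stated time of 72 h (on this read-out lower numbers stand for stronger inhibition of growth and higher numbers for weaker inhibition of growth), compound 1 (`CN(C)c1cccc2c(S(=O)(=O)N(CC(=O)NCc3ccccc3)Cc3ccc(C(=O)NO)cc3)cccc12`) gives 12900 nM and holds the higher of the two numbers so far, which marks the weaker growth inhibition. Compound 2 (`CN(C)c1cccc2c(S(=O)(=O)N(CCCCCC(=O)NO)CC(=O)NCc3ccccc3)cccc12`) gives 925 nM on the same read-out. Compound 3 (`CN(C)c1cccc2c(S(=O)(=O)N(CC(=O)NCc3ccccc3)Cc3ccc(C(=O)Nc4ccccc4N)cc3)cccc12`) keeps the core of compound 1 and the arm that carries the end group, and differs at one place: 2-aminophenyl in place of hydroxy on an amide-type nitrogen, so hydroxycarbamoyl becomes (2-aminophenyl)carbamoyl. Among the measured compounds shown here, the only measured step (a 14-fold lower number from compound 1 to compound 2 (1.14 log units; beyond the scatter)) is large, but it alters the arm and leaves the hydroxycarbamoyl group in place. For the measured compounds named here, no measured step exchanges the hydroxy. Going by the values given here, that step therefore shows only that numbers can move widely, and it gives no direction for compound 3. No step beyond the scatter is expected in this assay as the central case, with the range left wide on both sides. The estimated change (a 1.4-fold lower number from compound 1 to compound 3 (0.16 log units; within the scatter)) is expected to be small. For compound 3 the expected value is 9000 nM (estimated range 2000 nM to 35000 nM).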

Compound 3, concentration for 50% growth inhibition: 9100 nM
Estimate against measurement, compound 3: 1.0-fold (0.00 log units) below; the range from low to high includes it.
By their numbers in this assay, from the lowest: compound 2; then compounds 3 and 1 (each within the scatter of the next).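

In this assay, the exchange of hydroxy for 2-aminophenyl on the amide-type nitrogen, which turns hydroxycarbamoyl into (2-aminophenyl)carbamoyl, gives a 1.4-fold lower number from compound 1 to compound 3 (0.15 log units; within the scatter). Among these compounds, this is the first measured change at this position, and it shows that on the arm of compound 1 the end group can take on an aromatic ring without a step beyond the scatter, so this read-out does not separate the two end groups on that arm. Among the compounds shown here, the only step beyond the scatter remains a 14-fold lower number from compound 1 to compound 2 (1.14 log units; beyond the scatter), which alters the arm and not the end group, and no measurement at hand offers an explanation for either step.

On these data alone, it remains open whether the same exchange on the 4-(hydroxycarbamoyl)butyl arm of compound 2 would also stay within the scatter, since the result here covers only the 4-(hydroxycarbamoyl)phenyl arm. Also open, as far as these compounds go, is how other end groups at this position would read in this assay, for example a carboxylic acid in place of hydroxycarbamoyl, or a 2-hydroxyphenyl in place of 2-aminophenyl on the same nitrogen.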